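From 4-chlorophenyl to 3,4-dichlorophenyl at an assay limit

This account rests on a few compounds, and the source may have more. Where it says the series, first, only, none or still open, it means among the compounds named here.

Of the compounds shown here, three sharing one core have been tested in a functional assay on HepG2 cells (Homo sapiens) for cytotoxicity, with a stated time of 72 h; a lower number here means that less compound is needed, a higher number that more compound is needed for the effect. Compound 1 (`C=C[C@@](C)(/C=C/c1ccc(O)c(/C=C/C(=O)O)c1)CCC=C(C)C`), with a carboxy group on the double-bonded chain, gives > 52000 nM, which is a limit and not a number. Compound 2 (`C=C[C@@](C)(/C=C/c1ccc(O)c(/C=C/C(N)=O)c1)CCC=C(C)C`), with a carbamoyl group there, gives > 52000 nM, again only a limit. Compound 3 (`C=C[C@@](C)(/C=C/c1ccc(O)c(/C=C/c2ccc(Cl)cc2)c1)CCC=C(C)C`), with a 4-chlorophenyl group there, gives > 52000 nM, also only a limit. Compound 3 therefore has no number of its own, and the whole record so far is the limit of > 52000 nM in this assay, at which 3 of the 3 values shown sit.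

Compound 4 (`C=C[C@@](C)(/C=C/c1ccc(O)c(/C=C/c2ccc(Cl)c(Cl)c2)c1)CCC=C(C)C`) differs from compound 3 in one place. The change is chloro in place of hydrogen on an aromatic carbon, which turns 4-chlorophenyl into 3,4-dichlorophenyl.

The nearest measured changes are a step that the two limits leave unreadable from compound 1 to compound 3 and a step that the two limits leave unreadable from compound 2 to compound 3, and the remaining one is a step that the two limits leave unreadable from compound 1 to compound 2. None of these has a readable size, and none adds a second chloro, so no size or direction can be carried over. No step beyond the scatter is expected, and a further limit is the likeliest report.

Compound 4 is estimated at 60000 nM, with an expected range of 30000 nM to 120000 nM. The expected step is a step that the limit leaves unreadable from compound 3 to compound 4.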

Compound 4, half-maximal effective concentration: > 52000 nM
Compound 4: no number, only a limit; the forecaster's own chance of this, stated with the estimate: 75%; the middle value lies beyond the limit too.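

In this assay compound 4 gives > 52000 nM, which is a limit and not a number, so its steps from compound 1, compound 2 and compound 3 cannot be read. The record remains a single limit: the limit of > 52000 nM in this assay, at which 4 of the 4 values shown sit.

The compounds shown leave open how large any step among them is, and whether any group on the double-bonded chain of the shared core gives a measurable value.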